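The compounds below may be only part of what the source reports. "The series", "measured", "known", "first", "only" and "open" are said of these compounds alone.

Compound 2 `NCc1ccc(C(=O)Nc2ccncc2F)cc1-c1cccc(C(=O)OCC2CCCO2)c1` gives 2.5 nM in an assay on isolated protein for inhibition of Rho-associated protein kinase 2 (Homo sapiens), read by radiometric assay (on this read-out lower numbers stand for stronger inhibition and higher numbers for weaker inhibition), the lowest of the three numbers at hand; compound 3 `CCCCCOC(=O)c1cccc(-c2cc(C(=O)Nc3ccncc3)ccc2CN)c1` gives 4.9 nM, within the scatter of it, while compound 1 `CCCCCCOC(=O)c1cccc(-c2cc(C(=O)Nc3ccncc3)ccc2CN)c1` gives 22 nM, beyond the scatter. Compound 4 `COC(=O)c1cccc(-c2cc(C(=O)Nc3ccncc3F)ccc2CN)c1` differs from compound 2 by hydrogen in place of oxolan-2-yl on a saturated chain carbon bound to an oxygen next to a carbonyl group. Among the compounds with values here, the only measured step in that part of the molecule, a 4.5-fold lower number from compound 1 to compound 3 (0.65 log units; beyond the scatter), trimmed the chain end well away from the carbon bound to the oxygen next to the carbonyl group and lowered the number; removing a whole ring from that carbon itself is a different change, so it bears only loosely. A modest step in either direction, or none beyond the scatter, is therefore expected in this assay. Compound 4 is estimated at 6 nM, ranging 1.5 nM to 25 nM, a step of a 2.4-fold higher number from compound 2 to compound 4 (0.38 log units; beyond the scatter).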

Compound 4, half-maximal inhibitory concentration: 7.8 nM
Compound 4: middle estimate off by 1.3-fold (0.11 log units), on the low side, within the range that was stated.
By their numbers in this assay, from the lowest: compounds 2, 3 and 4 (each within the scatter of the next, the first and the last beyond it); then compound 1.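

The first step measured at the saturated chain carbon bound to an oxygen next to a carbonyl group itself, a 3.1-fold higher number from compound 2 to compound 4 (0.49 log units; beyond the scatter) in this assay, shows that the position responds to losing oxolan-2-yl. The step is modest, so the methoxycarbonyl compound needs no ring on that carbon to remain a nanomolar inhibitor. No measurement shown gives a reason for the size of this step. The compounds shown leave open whether an open chain such as 2-methoxyethyl would serve in place of (oxolan-2-yl)methyl. They also leave open how a carboxylic acid or an amide would compare with the ester.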